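A few compounds are considered here, and "the series" means these few. Any claim that something is new, unique, unknown or untested is made for them only; others in the source may bear on it.

Within the data shown here, in a functional assay on SiHa cells (Homo sapiens) for inhibition (a lower number here means a stronger inhibitor, a higher number a weaker inhibitor), compound 1 (`COc1cc(/C=C/C(=O)c2cccc(NC(=O)c3ccc(Cl)c(Cl)c3)c2)ccc1O`) gives 25.3 ug/mL and compound 2 (`CCCC(=O)Nc1cccc(C(=O)/C=C/c2ccc(O)c(OC)c2)c1`) gives 3.94 ug/mL as the lower of the two numbers so far. Compound 3 (`CCOC(=O)C(=O)Nc1cccc(C(=O)/C=C/c2ccc(O)c(OC)c2)c1`) carries ethoxycarbonyl in place of propyl on a carbonyl carbon and is not yet measured. Among the measured compounds shown here, the one measured step at this place (a 6.4-fold lower number from compound 1 to compound 2 (0.81 log units; beyond the scatter)) is modest and beyond the scatter, but it involves other groups and gives no direction for this change. A small move to a higher number is expected in this assay and may stay within the scatter. The expected step (a 1.5-fold higher number from compound 2 to compound 3 (0.18 log units; within the scatter)) is an estimate only. The estimate for compound 3 is 6 ug/mL (expected range 2 ug/mL to 18 ug/mL).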

Compound 3, half-maximal inhibitory concentration: > 50 ug/mL
Compound 3: only a limit was reported; the forecaster's own chance of this, stated with the estimate: 3%; middle value at least 8.3-fold (0.92 log units) from the limit.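

Compound 3 stands at a limit of the assay, not at a number: the limit of > 50 ug/mL in this assay, at which 1 of the 3 values shown sits. At this carbonyl carbon, whose other neighbour is the amide-type nitrogen, a short open-chain group does not by itself preserve the result in this assay: ethoxycarbonyl in place of propyl gives an at least 12-fold higher number from compound 2 to compound 3 (1.10 log units; beyond the scatter). Ethoxycarbonyl in place of 3,4-dichlorophenyl gives an at least 1.9-fold higher number from compound 1 to compound 3 (0.29 log units; that floor lies within the scatter), a floor that does not separate these two groups.

Open, on these data alone, is whether a longer alkyl chain, an amine or a carboxylic acid at this carbon stays near compound 2. Also open, as far as these compounds go, is whether a simple ethyl ether chain, without the added carbonyl, gives a similar step.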